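Ester chain lengthening on a pyrimidinone: expected stability

This account rests on a few compounds, and the source may have more. Where it says the series, first, only, none or still open, it means among the compounds named here.

Compound 1 `CCCCc1nc(C(C)C)c(CC(=O)OC)c(=O)n1Cc1ccc(-c2ccccc2-c2noc(=O)[nH]2)cc1`: 9.4%
Compound 2 `CCCCc1nc(C)c(CC(=O)OC)c(=O)n1Cc1ccc(-c2ccccc2-c2noc(=O)[nH]2)cc1`: 47.1%
Compound 3 `CCCCc1nc(C2CC2)c(CC(=O)OC(C)C)c(=O)n1Cc1ccc(-c2ccccc2-c2noc(=O)[nH]2)cc1`: 14%

In an ADME assay on microsomes from liver (Mus musculus) for metabolic stability, with a stated time of 30 min (a lower number here means that less of the compound is left, a higher number that more of the compound is left), compound 1 gives 9.4%, the lowest of the three numbers. Compound 3 gives 14%, which lies within the scatter of compound 1. Among the measured compounds shown here, compound 2 gives 47.1%, the only number separated from compound 1 beyond the scatter; the step of a number 37.7 percentage points higher from compound 1 to compound 2 (beyond the scatter) is large and comes from methyl in place of isopropyl on an aromatic carbon.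

Compound 4 `CCCCc1nc(C(C)C)c(C(C)C(=O)OCC)c(=O)n1Cc1ccc(-c2ccccc2-c2noc(=O)[nH]2)cc1` has not been measured. It differs from compound 1 by 1-(ethoxycarbonyl)ethyl in place of (methoxycarbonyl)methyl on an aromatic carbon. For the measured compounds named here, the isopropyl group on the aromatic carbon is kept, so the one measured step, which concerned that group, does not bear on this change. Going by the values given here, no measured step isolates the ester part alone, and the two values of compound 1 and compound 3 show no difference beyond the scatter. The account therefore expects no step beyond the scatter in this assay, with the estimate kept low. For compound 4 the expected value is 8%, estimated to lie between 2% and 20%. The expected step of a number 1.4 percentage points lower from compound 1 to compound 4 (within the scatter) is estimated to stay within the scatter.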

Compound 4, percent of the compound remaining: 28%
Compound 4: the middle estimate sits 20 percentage points below what was measured; measured number above the stated range.
By their numbers in this assay, from the lowest: compounds 1 and 3 (each within the scatter of the next); then compound 4; then compound 2.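

In this assay, 1-(ethoxycarbonyl)ethyl in place of (methoxycarbonyl)methyl gives a step of a number 18.6 percentage points higher from compound 1 to compound 4 (beyond the scatter) with the isopropyl group kept. The read-out therefore responds to a change at this position, on the aromatic carbon para to the butyl group, and not only to the isopropyl group changed in the earlier step. The compounds shown offer nothing that explains this step.

As far as these compounds go, the branching carbon and the ethyl ester enter together, and it stays open whether either one alone would give this step. Also open, from the compounds shown here alone, are how a carboxylic acid or a longer ester chain would read at this position, and whether the same change would hold with methyl in place of isopropyl.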